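Ring-nitrogen substituent on the shared core: sulfonyl to thiazolylcarbonyl

The compounds below may be only part of what the source reports. "The series", "measured", "known", "first", "only" and "open" are said of these compounds alone.

Measured so far:
compound 1 `CCCCNc1nc(N)nc2c1CN(S(C)(=O)=O)CC2` gives 9.9 uM
compound 2 `CCCCNc1nc(N)nc2c1CN(Cc1ccc(-c3ccccc3)cc1)CC2` gives 0.5 uM
compound 3 `CCCCNc1nc(N)nc2c1CN(Cc1cccc3ccccc13)CC2` gives 0.43 uM

All three were run in an assay on HEK293 cells for agonist activity at Toll-like receptor 8 (Homo sapiens), read by a luciferase reporter, with a stated time of 6 h; on this read-out higher numbers stand for an effect only at larger amounts of compound and lower numbers for an effect already at smaller amounts. Compound 1 stands at the highest number of the three; compound 2 and compound 3 lie far lower, each at a distance from compound 1 beyond the usual scatter, while compound 2 and compound 3 lie within the scatter of each other.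

Compound 4 `CCCCNc1nc(N)nc2c1CN(C(=O)c1csc(C)n1)CC2` has not been measured in this assay. It differs from compound 1 in one place: (2-methyl-1,3-thiazol-4-yl)carbonyl in place of methylsulfonyl on an amine nitrogen in a ring. Within the data shown here, no step between two measured compounds matches this change. What the measured numbers show is that exchanging the methylsulfonyl of compound 1 for a group carrying an aromatic ring goes with a much lower number, as compound 2 at 0.5 uM and compound 3 at 0.43 uM show. The group entering in compound 4 also carries an aromatic ring, joined through a carbonyl rather than a methylene. A step down in this assay is expected for compound 4, with the expected size set more cautiously than the steps seen for compound 2 or compound 3 given the different linkage. The estimate for compound 4 in this assay is 2 uM, with a range from 0.5 uM to 8 uM, which amounts to an expected step of a 5.0-fold lower number from compound 1 to compound 4 (0.69 log units; beyond the scatter).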

Compound 4, minimum effective concentration: 1.8 uM
The estimate for compound 4 lay 1.1-fold (0.05 log units) above the measured number; measured number inside the range.
By their numbers in this assay, from the lowest: compounds 3 and 2 (each within the scatter of the next); then compound 4; then compound 1.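

In this assay, (2-methyl-1,3-thiazol-4-yl)carbonyl in place of methylsulfonyl on an amine nitrogen in a ring gives a clear gain (a 5.5-fold lower number from compound 1 to compound 4 (0.74 log units; beyond the scatter)). A lower number at this position is therefore not confined to the methylene-linked groups of compound 2 and compound 3: a five-membered aromatic ring with 2 hetero atoms joined through a carbonyl also goes with one. The gain is partial, as compound 4 (1.8 uM) still stands above compound 2 (0.5 uM) and compound 3 (0.43 uM).

The compounds shown do not separate the linker from the ring, as no pair carries one aromatic group through both a methylene and a carbonyl. A (2-methyl-1,3-thiazol-4-yl)methyl group would test this directly, and a basic amine on the thiazole would probe the ring itself. No measurement here explains the step.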